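The compounds below may be only part of what the source reports. "The series", "measured", "known", "first", "only" and "open" are said of these compounds alone.

Going by the values given here, in a functional assay on the whole organism with Scenedesmus acutus as the target, with a stated time of 20 h (a lower number here means a stronger inhibitor, a higher number a weaker inhibitor), compound 2 `CC(C)COC(=O)c1cc(N2C(=O)C3=C(CCCC3)C2=O)ccc1Cl` gives 15500 nM, the higher of the two numbers measured so far. Among the compounds with values here, the only other measured compound, compound 1 `COC(=O)c1cc(N2C(=O)C3=C(CCCC3)C2=O)ccc1Cl`, gives 1620 nM. Compound 3 `CCC(C)OC(=O)c1cc(N2C(=O)C3=C(CCCC3)C2=O)ccc1Cl` awaits measurement and differs from compound 2 by a single change: sec-butyl in place of isobutyl on an oxygen next to a carbonyl group. It has the same atoms as compound 2, joined differently, with sec-butyl in place of isobutyl on an oxygen next to a carbonyl group. Within the data shown here, only one measured step bears on this change: a 9.6-fold higher number from compound 1 to compound 2 (0.98 log units; beyond the scatter). That step, which lies beyond the scatter, adds isopropyl, whereas the present change adds no atoms. Among the measured compounds shown here, no measured pair compares isobutyl with sec-butyl directly, so no step beyond the scatter is expected in this assay, in either direction. The expected step is a 1.3-fold lower number from compound 2 to compound 3 (0.11 log units; within the scatter). The estimate for compound 3 is 12000 nM, with a range of 4500 nM to 30000 nM.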

Compound 3, half-maximal inhibitory concentration: 9770 nM
Beside the measured number, compound 3's estimate is 1.2-fold (0.09 log units) above it, and the stated range covers the measured number.
By their numbers in this assay, from the lowest: compound 1; then compounds 3 and 2 (each within the scatter of the next).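

In this assay, moving from isobutyl to sec-butyl on the oxygen next to a carbonyl group gives a 1.6-fold lower number from compound 2 to compound 3 (0.20 log units; within the scatter), so this rearrangement of the same atoms does not separate the two compounds. The second step, a 6.0-fold higher number from compound 1 to compound 3 (0.78 log units; beyond the scatter), shows that the rise seen earlier with isobutyl, a 9.6-fold higher number from compound 1 to compound 2 (0.98 log units; beyond the scatter), is not unique to that group: sec-butyl in place of methyl also lies beyond the scatter, in the same direction. Nothing on hand explains these differences.

The compounds shown leave open how an unbranched chain such as ethyl or n-butyl would read at this place, and so whether branching plays any part in the rise. They also leave open how a carboxylic acid or an amide would read in place of this ester group.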